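Methyl to Hydrogen on Two Related Cores, Cytotoxicity Compared

The source may report more compounds than this note shows. Statements on the series, on what has been measured and on what is new or still open speak of the compounds shown alone.

Measured compounds:
compound 1, `CC(C)=CCC/C(C)=C/CC/C(C)=C/CSc1ccccc1C(=O)N[C@@H](C)C(=O)OC(C)CCOc1no[n+]([O-])c1S(=O)(=O)c1ccccc1`: 15300 nM
compound 2, `CC(C)=CCC/C(C)=C/CC/C(C)=C/CSc1ccccc1C(=O)N[C@@H](C)C(=O)OCCOCCOc1no[n+]([O-])c1S(=O)(=O)c1ccccc1`: 8040 nM
compound 3, `CC(C)=CCC/C(C)=C/CC/C(C)=C/CSc1ccccc1C(=O)NCC(=O)OC(C)CCOc1no[n+]([O-])c1S(=O)(=O)c1ccccc1`: 10800 nM

These three compounds were tested in a functional assay on U-251 cells (Homo sapiens) for cytotoxicity, read by MTT assay, with a stated time of 48 h; on this read-out lower numbers stand for stronger inhibition and higher numbers for weaker inhibition. Compound 3 differs from compound 1 by hydrogen in place of methyl on a saturated chain carbon bound to an amide-type nitrogen and a carbonyl carbon, and this change gave a 1.4-fold lower number from compound 1 to compound 3 (0.15 log units; within the scatter). Compound 2 and compound 1 share only part of their structure; the difference between the two cores is not broken down here.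

Compound 4, `CC(C)=CCC/C(C)=C/CC/C(C)=C/CSc1ccccc1C(=O)NCC(=O)OCCOCCOc1no[n+]([O-])c1S(=O)(=O)c1ccccc1`, has not yet been measured. It differs from compound 2 by hydrogen in place of methyl on a saturated chain carbon bound to an amide-type nitrogen and a carbonyl carbon, the same change as that from compound 1 to compound 3. Because the earlier step was a 1.4-fold lower number from compound 1 to compound 3 (0.15 log units; within the scatter), the step in this assay is expected to be of similar size, a 1.3-fold lower number from compound 2 to compound 4 (0.13 log units; within the scatter). Compound 4 is therefore estimated at 6000 nM, with a likely range from 3000 nM to 13000 nM.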

Compound 4, half-maximal inhibitory concentration: 8580 nM
Estimate against measurement, compound 4: 1.4-fold (0.16 log units) below, and the stated range covers the measured number.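

Hydrogen in place of methyl on a saturated chain carbon bound to an amide-type nitrogen and a carbonyl carbon gave a 1.1-fold higher number from compound 2 to compound 4 (0.03 log units; within the scatter) in this assay. Set beside the same change on the other core, the two steps do not differ beyond the scatter: the same change on two cores in this assay, a 1.4-fold lower number (0.15 log units; within the scatter) from compound 1 to compound 3 and a 1.1-fold higher number (0.03 log units; within the scatter) from compound 2 to compound 4, 1.5-fold (0.18 log units) apart, within the scatter of two such steps. This shows that the change carried from one core to the other without a readable difference, but since each step is itself within the scatter, it shows neither a real effect of the methyl on either core nor a direction for one.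

The compounds shown leave open what an ethyl or a benzyl group in place of that methyl would do in this assay. They also leave open whether the result holds on any core beyond these two.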